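Ketone heteroaryl swap in a diacylglycerol lipase-alpha series

A few compounds are considered here, and "the series" means these few. Any claim that something is new, unique, unknown or untested is made for them only; others in the source may bear on it.

Two compounds share a long chain ending in a phenyl group, joined through a carbonyl to a five-membered aromatic ring. In an assay on HEK-293T cells for inhibition of diacylglycerol lipase-alpha (Homo sapiens), read by colorimetric assay (a higher number here means a weaker inhibitor, a lower number a stronger inhibitor), compound 1 `O=C(CCCCCCc1ccccc1)c1nc(C(F)(F)F)co1` gives 214 nM. Compound 2 `O=C(CCCCCCc1ccccc1)c1nc(Cl)co1` gives 2400 nM, the higher of the two numbers and so the weaker inhibitor, with the step of an 11-fold higher number from compound 1 to compound 2 (1.05 log units; beyond the scatter). Compound 3 `O=C(CCCCCCc1ccccc1)c1ncno1` is not yet measured. The change is 1,2,4-oxadiazol-5-yl in place of 4-chloro-1,3-oxazol-2-yl on a carbonyl carbon. Within the data shown here, no measured step covers this kind of exchange; the only step known swaps a substituent on the ring and is large, which shows the ring end of the molecule matters. Compound 3 is therefore expected to move somewhat further toward weaker inhibition, by a 2.1-fold higher number from compound 2 to compound 3 (0.32 log units; beyond the scatter), with wide uncertainty. Compound 3 is estimated at 5000 nM, within a range from 1500 nM to 20000 nM.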

Compound 3, half-maximal inhibitory concentration: > 10000 nM
Compound 3: only a limit was reported; the forecaster's own chance of this, stated with the estimate: 15%; at least 2.0-fold (0.30 log units) between middle value and limit.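

The earlier pair changed only a substituent on the ring, whereas this result shows that exchanging the whole ring on the carbonyl carbon also matters, with an at least 4.1-fold higher number from compound 2 to compound 3 (0.61 log units; beyond the scatter) as the outcome of that exchange. The 1,2,4-oxadiazol-5-yl group, with its extra ring hetero atom and no chloro substituent, therefore does not retain the inhibition seen with 4-chloro-1,3-oxazol-2-yl. In this assay, on these data alone, compound 3 has only a limit, so the true size of the step remains unknown: the limit of > 10000 nM in this assay, at which 1 of the 3 values shown sits.

Still open, as far as these compounds go, is whether a trifluoromethyl group or a nitrile on the 1,2,4-oxadiazol-5-yl ring would restore inhibition. The compounds shown also leave open how a shorter chain in place of the chain ending in phenyl would behave with either ring.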